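Pyrrolidin-1-yl in place of methylsulfanyl: an expected small step

The source may hold more compounds than are shown below. What is called first, only, known or untested is meant among the compounds shown, and "the series" means these compounds.

Compound 1 `CSc1nc(Cl)c(C(=O)c2ccccc2)s1` gives in a functional assay on A549 cells (Homo sapiens) for cytotoxicity, read by MTT assay, with a stated time of 72 h (on this read-out higher numbers stand for weaker inhibition and lower numbers for stronger inhibition), only a limit of the assay, > 100000 nM.
Compound 2 `CSc1nc(Br)c(C(=O)c2ccccc2)s1` gives in this assay 97000 nM.
Compound 3 `CCOC(=O)c1sc(N2CCCC2)nc1Cl` gives in this assay 61000 nM.

Compound 2 and compound 3 lie within the usual scatter of each other, and compound 1 offers only a limit (the limit of > 100000 nM in this assay, at which 1 of the 3 values shown sits). Among the measured compounds shown here, the one measured step, an at least 1.0-fold lower number from compound 1 to compound 2 (0.01 log units; that floor lies within the scatter), stays within the scatter. Compound 4 `O=C(c1ccccc1)c1sc(N2CCCC2)nc1Br` differs from compound 2 by pyrrolidin-1-yl in place of methylsulfanyl on an aromatic carbon. For the measured compounds named here, no measured step follows this exchange directly; compound 3, which also carries pyrrolidin-1-yl, sits close to compound 2. A step of a 1.3-fold lower number from compound 2 to compound 4 (0.11 log units; within the scatter) is therefore expected, none beyond the scatter. Compound 4 is estimated at 75000 nM, between 25000 nM and 200000 nM.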

Compound 4, half-maximal inhibitory concentration: 97000 nM
Beside the measured number, compound 4's estimate is 1.3-fold (0.11 log units) below it; measured number inside the range.
By their numbers in this assay, from the lowest: compounds 3, 2 and 4 (each within the scatter of the next). At a limit, above all of these: compound 1.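

Pyrrolidin-1-yl in place of methylsulfanyl, on the aromatic carbon next to the ring nitrogen and next to the ring sulfur, can now be read directly: in this assay the exchange gives no change at the digits printed from compound 2 to compound 4 (within the scatter). With the bromo group and the rest of the core held fixed, this position thus accepts the larger group with its ring, with no readable shift in the number. Compound 2 and compound 4 both stand close to a limit of the assay: the limit of > 100000 nM in this assay, at which 1 of the 4 values shown sits.

As far as these compounds go, whether a carboxylic acid or a longer amine chain at this position would move the number beyond the scatter stays open.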